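A few compounds are considered here, and "the series" means these few. Any claim that something is new, unique, unknown or untested is made for them only; others in the source may bear on it.

Compound 1 `Cc1nc2ccccc2n1-c1csc(Nc2ccc(S(N)(=O)=O)cc2)n1`: 45000 nM
Compound 2 `Cc1cn(-c2csc(Nc3cccc(Br)c3)n2)c(C)n1`: > 100000 nM

In a functional assay on RKO cells (Homo sapiens) for cytotoxicity, read by resazurin assay, with a stated time of 72 h (on this read-out lower numbers stand for stronger inhibition and higher numbers for weaker inhibition), compound 1 gives 45000 nM, and this is the only number among the two results shown. Compound 2 is reported in this assay only as a limit, > 100000 nM, not as a number. Compound 1 therefore stands alone as the single quantified point, with one result above the range of the assay beside it; the summary of the measured results reads (the limit of > 100000 nM in this assay, at which 1 of the 2 values shown sits).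

Compound 3 `COc1ccc(Nc2nc(-n3c(C)nc4ccccc43)cs2)cc1` has not been measured in this assay. It differs from compound 1 in one place: methoxy in place of sulfamoyl on an aromatic carbon. Among the compounds with values here, no step between measured compounds that differ in a single place is available, so there is nothing in the data to set the size or direction of this change. The expectation is a step from compound 1 of a 1.1-fold higher number from compound 1 to compound 3 (0.05 log units; within the scatter), that is, none beyond the usual scatter. Compound 3 is therefore estimated at 50000 nM, with a range from 15000 nM to 150000 nM, and a real chance that the assay returns only a limit.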

Compound 3, half-maximal inhibitory concentration: 25 nM
Compound 3: the middle estimate sits 2000-fold (3.30 log units) above what was measured; measured number below the stated range.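

Replacing sulfamoyl with methoxy on an aromatic carbon, para to a large group, gives a 1800-fold lower number from compound 1 to compound 3 (3.26 log units; beyond the scatter) in this assay with the rest of the structure unchanged, so this one place can decide whether a compound reads as weak or strong on this measure. Within the data shown here, no earlier pair of measured compounds differed in a single place, and the sensitivity of the read-out to this position could not be seen until this step. Nothing measured here gives a property of either group that would account for the size of the step.

A single pair cannot tell whether the step follows the loss of sulfamoyl or the arrival of methoxy, and the compounds shown include no plain hydrogen, hydroxyl, ethoxy or amine at this place that could separate the two. As far as these compounds go, it also remains open whether methoxy has the same effect elsewhere on this ring or on a different core, and compound 2 differs from the other two compounds in more than one place and offers no comparison.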